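A few compounds are considered here, and "the series" means these few. Any claim that something is new, unique, unknown or untested is made for them only; others in the source may bear on it.

Three close relatives share a core in which an oxime-bearing amide links a fluoro-bromo-substituted benzene ring to a saturated six-membered ring, and each has been tested in an assay for inhibition of Tryptophan 2,3-dioxygenase (Homo sapiens), with a stated time of 1 h; a lower number here means a stronger inhibitor, a higher number a weaker inhibitor. Compound 1 `O=C(/C(=N/O)Nc1ccc(F)c(Br)c1)C1CCN(C(=O)NCc2ccccc2)CC1` carries a benzylurea on a nitrogen-containing saturated ring and gives 89800 nM in this assay. Compound 2 `O=C(/C(=N/O)Nc1ccc(F)c(Br)c1)C1CCCCC1` has the bare saturated ring of carbon only and gives 79300 nM. Compound 3 `O=C(Nc1ccccc1)[C@H]1CC[C@H](C(=O)/C(=N/O)Nc2ccc(F)c(Br)c2)CC1` adds a phenylcarbamoyl group to that ring. In this assay compound 3 reaches only the limit of > 100000 nM, which is a boundary of the measurement and not a number. The step of an at least 1.2-fold higher number from compound 2 to compound 3 (0.10 log units; that floor lies within the scatter) therefore says little, since it rests on (the limit of > 100000 nM in this assay, at which 1 of the 3 values shown sits).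

Compound 4 `O=C(NC[C@H]1CC[C@H](C(=O)/C(=N/O)Nc2ccc(F)c(Br)c2)CC1)c1ccccc1` differs from compound 3 in one place: benzamidomethyl in place of phenylcarbamoyl on a saturated ring carbon. For the measured compounds named here, the only measured step that bears on it is the one from compound 2 to compound 3, which did not leave the scatter, and compound 1, with a related benzyl-bearing group, sits near the same weak level. Compound 4 is therefore expected to remain a weak inhibitor, with an estimated step that the limit leaves unreadable from compound 3 to compound 4 that stays within the scatter. For compound 4 the expected value in this assay is 110000 nM, with a range from 50000 nM to 250000 nM.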

Compound 4, half-maximal inhibitory concentration: 81000 nM
The estimate for compound 4 lay 1.4-fold (0.13 log units) above the measured number; measured number inside the range.
By their numbers in this assay, from the lowest: compounds 2, 4 and 1 (each within the scatter of the next). At a limit, above all of these: compound 3.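

In this assay, for the compounds shown here, compound 4 gives a measured number where compound 3 gave only a limit, so benzamidomethyl on this saturated ring carbon yields the first readable value for a large group at this place on the all-carbon ring. That value matches the bare ring, with a 1.0-fold higher number from compound 2 to compound 4 (0.01 log units; within the scatter), so here this large group brings no readable gain or loss compared with hydrogen. The other step, an at least 1.2-fold lower number from compound 3 to compound 4 (0.09 log units; that floor lies within the scatter), says little about benzamidomethyl against phenylcarbamoyl, since one end of it is a limit: the limit of > 100000 nM in this assay, at which 1 of the 4 values shown sits.

On these data alone, whether an amine or a carboxylic acid on this ring carbon would give a number clearly lower than those of compound 2 and compound 4 stays open. None of the compounds shown has yet moved beyond the scatter of the others.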